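Phenyl for Thiophene on a Nucleoside Core

The source may hold more compounds than are shown below. What is called first, only, known or untested is meant among the compounds shown, and "the series" means these compounds.

Of the compounds shown here, three have been measured in a functional assay on HL-60 cells (Homo sapiens) for antiproliferative activity, read by XTT assay, with a stated time of 72 h; on this read-out lower numbers stand for stronger inhibition and higher numbers for weaker inhibition.
Compound 1 `Cc1nc(N)c2c(-c3ccccc3)cn([C@@H]3O[C@H](CO)[C@@H](O)[C@H]3O)c2n1` gives > 20000 nM, which is a limit of the assay and not a number.
Compound 2 `Cc1nc(N)c2c(-c3cccs3)cn([C@@H]3O[C@H](CO)[C@@H](O)[C@H]3O)c2n1` gives > 20000 nM, again a limit of the assay rather than a number.
Going by the values given here, compound 3 `COc1ncnc2c1c(-c1cccs1)cn2[C@@H]1O[C@H](CO)[C@@H](O)[C@H]1O` gives 80 nM, the only number among the three.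

Compound 1 and compound 2 share a core and differ only by phenyl in place of thiophen-2-yl on an aromatic carbon. The step that the two limits leave unreadable from compound 2 to compound 1 cannot be read because both compounds sit at the limit of > 20000 nM in this assay, at which 2 of the 3 values shown sit, so this pair says nothing about the size or direction of the change. The core of compound 3 differs from the core of compound 2, but that difference is not broken down here.

Compound 4 `COc1ncnc2c1c(-c1ccccc1)cn2[C@@H]1O[C@H](CO)[C@@H](O)[C@H]1O` has the core of compound 3 and differs from it by phenyl in place of thiophen-2-yl on an aromatic carbon. This is the same change as the one from compound 2 to compound 1, made at the same place, and it occurs twice among the compounds shown; its one measured instance gives no readable size. The expectation for compound 4 therefore rests on compound 3 and its value 80 nM, with the exchanged group being a small part of the molecule.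

The step from compound 3 to compound 4 in this assay is expected to be a 1.9-fold higher number from compound 3 to compound 4 (0.27 log units; within the scatter), a change that would stay within the usual scatter. Compound 4 is expected to give about 150 nM in this assay. For compound 4 the estimate is expected to lie between 40 nM and 600 nM.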

Compound 4, half-maximal inhibitory concentration: > 20000 nM
Compound 4: no number, only a limit (the forecaster's own chance of this, stated with the estimate: 10%); middle value at least 130-fold (2.12 log units) away from the limit.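

Phenyl in place of thiophen-2-yl on an aromatic carbon gives an at least 250-fold higher number from compound 3 to compound 4 (2.39 log units; beyond the scatter) in this assay, so on the core of compound 3 this single exchange separates a measured value from a reading with no number. The same exchange on the core of compound 2 cannot be read, so the compounds shown neither confirm nor rule out that the change acts alike on both cores, and a single readable pair establishes no rule for the series. The size of the readable step is also only a bound and not a measured difference, since the reading for compound 4 is a limit of the assay and not a number: the limit of > 20000 nM in this assay, at which 3 of the 4 values shown sit.

As far as these compounds go, what a furan-2-yl or thiophen-3-yl ring, or a plain methyl, would give on that aromatic carbon of the core of compound 3 remains open, and so does whether activity there depends on thiophen-2-yl specifically. Also open, from the compounds shown here alone, is which part of the difference between the two cores matters, for instance the methoxy group as against an amine, since that difference is not resolved into single changes here.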